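From 2-hydroxyethyl to 3-hydroxycyclobutyl on the shared core

The source may hold more compounds than are shown below. What is called first, only, known or untested is meant among the compounds shown, and "the series" means these compounds.

In a physicochemical assay for solubility, in phosphate buffer, at pH 7.4 (on this read-out higher numbers stand for higher solubility and lower numbers for lower solubility), compound 1 `CNC(=O)Nc1cc(Oc2cncc(C)c2)c(CCCO)cn1` gives 500000 nM and compound 2 `CNC(=O)Nc1cc(Oc2cncc(C)c2)c(CCO)cn1` gives 450000 nM. For the measured compounds named here, these two numbers lie within the scatter of each other, so compound 2 stands level with the only other measured compound.

Compound 3 `CNC(=O)Nc1cc(Oc2cncc(C)c2)c([C@H]2C[C@@H](O)C2)cn1` keeps the core of compound 2 and carries 3-hydroxycyclobutyl in place of 2-hydroxyethyl on an aromatic carbon.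

Going by the values given here, only one measured step bears on this change. It is hydroxy in place of hydroxymethyl on a saturated chain carbon, and a 1.1-fold lower number from compound 1 to compound 2 (0.05 log units; within the scatter). That step shows little about the new change, as it stays within a chain with no ring. Among the compounds with values here, no compound with a ring at this place has been measured in this assay, so the direction rests on judgement alone and the range is kept wide.

A modest move to a lower number is expected, with the estimated change being a 1.8-fold lower number from compound 2 to compound 3 (0.26 log units; within the scatter). For compound 3 the estimated value is 250000 nM, with an expected range of 80000 nM to 500000 nM.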

Compound 3, solubility: 332000 nM
The estimate for compound 3 lay 1.3-fold (0.12 log units) below the measured number; measured number inside the range.
By their numbers in this assay, from the lowest: compounds 3, 2 and 1 (each within the scatter of the next).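

Working notes on the position on the aromatic carbon, two atoms from the ring nitrogen and para to the (methylcarbamoyl)amino group. For the compounds shown here, this is the first ring at this place, and in this assay the change to 3-hydroxycyclobutyl stays within the scatter of the 2-hydroxyethyl compound (a 1.4-fold lower number from compound 2 to compound 3 (0.13 log units; within the scatter)). It also stays within the scatter of the 3-hydroxypropyl compound (a 1.5-fold lower number from compound 1 to compound 3 (0.18 log units; within the scatter)). Across compounds 1, 2 and 3, then, neither the four-membered carbon ring with its two defined stereocentres nor the difference in heavy atoms separates the read-outs, and none of the three compounds goes against this. No supporting data bear on why the numbers stay level.

On these data alone, all three groups at this place carry a hydroxy group on a saturated carbon, so it remains open whether the read-out stays level with an amine, a carboxylic acid or a methoxy group there. Also open, as far as these compounds go, are the other stereoisomer of 3-hydroxycyclobutyl, and whether a longer hydroxyalkyl chain or a larger saturated ring at this place would give a step beyond the scatter.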